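A few compounds are considered here, and "the series" means these few. Any claim that something is new, unique, unknown or untested is made for them only; others in the source may bear on it.

Measured so far:
Compound 1, `CC(C)(C)c1ccc(CNCCCNS(=O)(=O)c2cc(C(F)(F)F)cc(C(F)(F)F)c2)cc1`: 2700 nM
Compound 2, `CN(CCCNS(=O)(=O)c1cc(C(F)(F)F)cc(C(F)(F)F)c1)Cc1ccccc1`: 51000 nM

In a functional assay on ASPC1 cells (Homo sapiens) for inhibition, read by MTT assay, with a stated time of 72 h (on this read-out lower numbers stand for stronger inhibition of growth and higher numbers for weaker inhibition of growth), compound 1 gives the lowest of the two numbers, and compound 2 gives a number that lies well beyond the usual scatter above it, so compound 1 inhibits growth more strongly of the two. Compound 3, `O=S(=O)(NCCCNCc1ccccc1)c1cc(C(F)(F)F)cc(C(F)(F)F)c1`, has not yet been tested in this assay. It differs from compound 1 in one place: hydrogen in place of tert-butyl on an aromatic carbon. Compound 2 and compound 3 share a benzyl group without the tert-butyl, and compound 2 gave a weak result, so losing the tert-butyl looks costly. The step expected here is a 5.6-fold higher number from compound 1 to compound 3 (0.74 log units; beyond the scatter), meaning a clearly weaker inhibition of growth, beyond the scatter. Compound 3 is thus expected to give about 15000 nM, most likely falling between 4000 nM and 50000 nM.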

Compound 3, concentration for 50% growth inhibition: 13000 nM
Compound 3: the middle estimate sits 1.2-fold (0.06 log units) above what was measured, and the stated range covers the measured number.
By their numbers in this assay, from the lowest: compound 1; then compound 3; then compound 2.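

In this assay the change from 4-(tert-butyl)benzyl to benzyl now has a size of its own, with a 4.8-fold higher number from compound 1 to compound 3 (0.68 log units; beyond the scatter) showing that the tert-butyl matters at this place, although compound 3 still inhibits growth without it. On the amine nitrogen, hydrogen in place of methyl brings a separate gain, with a 3.9-fold lower number from compound 2 to compound 3 (0.59 log units; beyond the scatter) showing that the free amine hydrogen goes with stronger inhibition in this pair. Nothing shown here explains why either change has this effect.

Going by these compounds, whether a smaller group such as methyl or chlorine at the place of the tert-butyl would keep part of the gain remains open. Also open, on these data alone, are how an ethyl group on the amine nitrogen or a longer chain in the linker would behave, and whether methyl on that nitrogen costs as much when the tert-butyl is present.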